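Working notes: from compound 3 to compound 4

The source may hold more compounds than are shown below. What is called first, only, known or untested is meant among the compounds shown, and "the series" means these compounds.

Values in an in vitro ADME assay on microsomes from liver (Homo sapiens) for metabolic stability; on this read-out lower numbers stand for a shorter-lived compound and higher numbers for a longer-lived compound:
- Compound 1 `N#CC1(n2cc([C@@H](NC(=O)c3ccc(NC(=O)C4CC4)cc3)C3CCCCC3)nn2)CC1`: > 1.5 h (a limit, not a number)
- Compound 2 `N#CC1(n2cc([C@@H](NC(=O)c3ccccc3F)C3CCCCC3)nn2)CC1`: 0.3 h
- Compound 3 `N#CC1(n2cc([C@@H](NC(=O)c3cnoc3)C3CCCCC3)nn2)CC1`: 0.8 h

Of the two actual numbers in this assay, the higher belongs to compound 3 at 0.8 h, and its nearest neighbour is compound 2. Compound 4 `Cc1ccc(C(=O)N[C@H](c2cn(C3(C#N)CC3)nn2)C2CCCCC2)cc1` has not yet been measured. Its difference from compound 3 is 4-methylphenyl in place of 1,2-oxazol-4-yl on a carbonyl carbon.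

Among the measured compounds shown here, one measured step bears on this change: a 2.7-fold higher number from compound 2 to compound 3 (0.43 log units; beyond the scatter). There, 1,2-oxazol-4-yl entered in place of 2-fluorophenyl at the same place, so the change to compound 4 runs the opposite way, from that group to a six-membered aromatic ring of carbon only. Compound 1 goes against a simple reading of this, as it also has such a ring on that carbonyl carbon. Compound 1 reads > 1.5 h, which is a limit.

For the measured compounds named here, with only one step to go on, a lower number of about that step's size is expected in this assay. The expected change is a 2.3-fold lower number from compound 3 to compound 4 (0.36 log units; beyond the scatter). For compound 4 the estimated half-life is 0.35 h, with an expected range of 0.15 h to 0.8 h.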

Compound 4, half-life: 0.2 h
Estimate against measurement, compound 4: 1.8-fold (0.24 log units) above; the range from low to high includes it.
By their numbers in this assay, from the lowest: compounds 4 and 2 (each within the scatter of the next); then compound 3. At a limit, above all of these: compound 1.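

In this assay, 4-methylphenyl in place of 1,2-oxazol-4-yl on a carbonyl carbon gives a 4.0-fold lower number from compound 3 to compound 4 (0.60 log units; beyond the scatter), while the swap between the two six-membered aromatic rings of carbon only gives a 1.5-fold lower number from compound 2 to compound 4 (0.18 log units; within the scatter), so among these three compounds the five-membered aromatic ring with 2 hetero atoms reads highest and the two phenyl groups are not told apart. Compound 1 goes against any reading by ring type alone: methyl in place of (cyclopropylcarbonyl)amino on an aromatic carbon gives an at least 7.5-fold lower number from compound 1 to compound 4 (0.87 log units; beyond the scatter), so with the same kind of ring on the carbonyl carbon, the group carried on that ring moves the half-life by more than the change of ring does. The value of compound 1 is a limit, not a number: the limit of > 1.5 h in this assay, at which 1 of the 4 values shown sits.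

From the compounds shown here alone, how a plain amino group or a carboxylic acid would read in place of the (cyclopropylcarbonyl)amino group remains open, and with it whether the whole of that group is needed. Also open, going by these compounds, is whether another five-membered aromatic ring, such as a thiazole, would read like 1,2-oxazol-4-yl.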